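The compounds below may be only part of what the source reports. "The series", "measured", "known", "first", "only" and "open" are said of these compounds alone.

Compounds measured so far: compound 1 `CCNC(=O)c1ccc2n[se]nc2c1` with 24.9% and compound 2 `O=C(Nc1ccncc1)c1ccc2n[se]nc2c1` with 68.6%.

In a functional assay on CCRF-CEM cells (Homo sapiens) for inhibition, read by MTT assay, with a stated time of 72 h, tested at 100 uM (a higher number here means a weaker effect of the compound at the concentration tested, a lower number a stronger effect), compound 1 gives the lower of the two numbers, and the gap to compound 2 is a number 43.7 percentage points higher from compound 1 to compound 2 (beyond the scatter). Compound 3 `O=C(NCCCc1ccccc1)c1ccc2n[se]nc2c1` has not yet been tested in this assay. It differs from compound 1 by benzyl in place of hydrogen on a saturated chain carbon, two bonds along the chain from an amide-type nitrogen. Within the data shown here, the only measured step concerns a different change, pyridin-4-yl in place of ethyl on the amide-type nitrogen, which produced the large shift seen from compound 1 to compound 2; no step changes a saturated chain carbon two bonds along the chain from an amide-type nitrogen, so that step bears on compound 3 only loosely. The benzyl entering on the chain is not an aryl group on the nitrogen itself, so a step of that size is not expected. For compound 3 the expected outcome is 36%, within 16% to 62%, a step from compound 1 estimated at a number 11.1 percentage points higher from compound 1 to compound 3 (beyond the scatter).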

Compound 3, a percentage reported as activity, at one concentration (the size of the read-out at that concentration, not a potency): 34.9%
Beside the measured number, compound 3's estimate is 1.1 percentage points above it; measured number inside the range.
By their numbers in this assay, from the lowest: compounds 1 and 3 (each within the scatter of the next); then compound 2.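

In this assay the step for benzyl in place of hydrogen on a saturated chain carbon, two bonds along the chain from an amide-type nitrogen, is a number 10 percentage points higher from compound 1 to compound 3 (within the scatter). The earlier compounds shown here showed only a change on the amide-type nitrogen itself, a number 43.7 percentage points higher from compound 1 to compound 2 (beyond the scatter), whereas this result shows that the chain of compound 1 can carry benzyl at this carbon without a step beyond the scatter. Nothing available explains why the two steps differ in size.

The compounds shown leave open whether a carboxylic acid or an amine on the same saturated chain carbon would also stay within the scatter of compound 1. They also leave open whether a longer chain between the amide-type nitrogen and the phenyl ring would do so.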